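A few compounds are considered here, and "the series" means these few. Any claim that something is new, unique, unknown or untested is made for them only; others in the source may bear on it.

Compound 1 `COc1cc2c(cc1OC)C(=O)C(C(=O)Nc1ccc(Cl)cc1)C2` has been measured in a physicochemical assay, with a stated time of 30 min (on this read-out higher numbers stand for weaker inhibition and lower numbers for stronger inhibition), where compound 1 gives 56.8 ug/mL. Among the measured compounds shown here, only one other compound is measured, compound 2 `COc1cc2c(cc1OC)C(=O)C(C(=O)Nc1cccc(Br)c1)C2`, which in this assay gives 58.9 ug/mL; the gap between compound 1 and compound 2 lies within the scatter, so neither can be called the stronger or weaker inhibitor. For the measured compounds named here, the single measured step, a 1.0-fold higher number from compound 1 to compound 2 (0.02 log units; within the scatter), puts 3-bromophenyl in place of 4-chlorophenyl on the amide-type nitrogen and leaves the number essentially unchanged.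

The next compound, compound 3 `COc1cc2c(cc1OC)C(=O)C(C(=O)Nc1ccccc1F)C2`, differs from compound 1 in one place: 2-fluorophenyl in place of 4-chlorophenyl on an amide-type nitrogen. Going by the values given here, the one step that bears on this, a 1.0-fold higher number from compound 1 to compound 2 (0.02 log units; within the scatter), exchanged one halogen-bearing phenyl for another on the amide-type nitrogen and stayed within the scatter. The new change is of the same kind, though no fluorine-bearing phenyl has yet been measured, so the range is kept wide. For compound 3 the expected step is a 1.1-fold higher number from compound 1 to compound 3 (0.02 log units; within the scatter), that is, no step beyond the scatter in this assay. Compound 3 is estimated at 60 ug/mL, between 30 ug/mL and 120 ug/mL.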

Compound 3, half-maximal inhibitory concentration: 75.7 ug/mL
Estimate against measurement, compound 3: 1.3-fold (0.10 log units) below, and the stated range covers the measured number.
By their numbers in this assay, from the lowest: compounds 1, 2 and 3 (each within the scatter of the next).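

In this assay the amide-type nitrogen now carries a third halogen-bearing phenyl, and the exchange gives a 1.3-fold higher number from compound 1 to compound 3 (0.12 log units; within the scatter) with 2-fluorophenyl replacing 4-chlorophenyl, and a 1.3-fold higher number from compound 2 to compound 3 (0.11 log units; within the scatter) with 2-fluorophenyl replacing 3-bromophenyl. Compound 3 thus adds the first fluorine-bearing phenyl to the series, and across compounds 1, 2 and 3 no exchange among these three groups takes the number beyond the scatter, with no compound shown going against this. No measured evidence bears on why the number shows no clear step at this position.

Each step changes the halogen and the number in the group name together, so the contribution of each cannot be separated with these compounds. Also open, going by these compounds, is whether an unsubstituted phenyl, a phenyl carrying an amine or a carboxylic acid, or a longer alkyl chain on the amide-type nitrogen would give a step beyond the scatter in this read-out.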